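A few compounds are considered here, and "the series" means these few. Any claim that something is new, unique, unknown or untested is made for them only; others in the source may bear on it.

Measured so far:
Compound 1 `COc1ccc(-c2cnc(NC(=O)c3ccno3)n2C)cc1`: in a toxicity assay on THP-1 cells (Homo sapiens) for inhibition (a higher number here means that more compound is tolerated, a lower number that less compound is tolerated), compound 1 gives > 100000 nM, which is a limit of the assay.
Compound 2 `COc1ccc(-c2cnc(NC(=O)c3ccc(F)cc3)n2C)cc1`: in this assay compound 2 gives >= 50000 nM, again a limit of the assay.

Within the data shown here, compound 2 therefore stands at a limit in this assay, not at a number, and the only other value known is likewise a limit. The step that the two limits leave unreadable from compound 1 to compound 2 has no readable size: the limit of > 100000 nM in this assay, at which 1 of the 2 values shown sits, and the limit of >= 50000 nM in this assay, at which 1 of the 2 values shown sits, leave open whether anything changed at all.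

The compound to be measured is compound 3 `COc1ccc(-c2cnc(NC(=O)C3CCOCC3)n2C)cc1`. It differs from compound 2 in one place: oxan-4-yl in place of 4-fluorophenyl on a carbonyl carbon. Among the measured compounds shown here, the one measured step that bears on the same position is the step from compound 1 to compound 2, and since its size is unreadable, no measured step points to a direction or a size in this assay. Because compound 2 reaches only a limit >= 50000 nM, compound 3 is expected to be tolerated to a similar degree. The expected step that the limit leaves unreadable from compound 2 to compound 3 is estimated to be none beyond the scatter. Compound 3 is estimated at 80000 nM, within a range from 30000 nM to 200000 nM.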

Compound 3, half-maximal cytotoxic concentration: > 100000 nM
Compound 3 ended at the assay's limit; the forecaster's own chance of this, stated with the estimate: 70%; middle value at least 1.2-fold (0.09 log units) from the limit.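

In this assay, among these compounds, compound 1, compound 2 and compound 3 all stand at limits of the assay and not at numbers, so no step among them can be read. The compounds shown leave open at what concentration, if any, each of them harms these cells, and whether the group on the carbonyl carbon changes that concentration.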